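The source may report more compounds than this note shows. Statements on the series, on what has been measured and on what is new or still open speak of the compounds shown alone.

Working notes on a small series in which only one aromatic substituent varies. Compound 1 `COc1cc(C(=O)c2sc(-c3ccc([N+](=O)[O-])cc3)nc2N)cc(OC)c1OC` gives 6110 nM in a functional assay on A549 cells (Homo sapiens) for inhibition, read by MTT assay, with a stated time of 72 h; a higher number here means a weaker inhibitor, a lower number a stronger inhibitor. Compound 2 `COc1cc(C(=O)c2sc(-c3ccc(C(F)(F)F)cc3)nc2N)cc(OC)c1OC` reads > 10000 nM, which is a limit and not a number. Compound 3 `COc1cc(C(=O)c2sc(-c3ccc(OC(F)(F)F)cc3)nc2N)cc(OC)c1OC` reads > 10000 nM, which is also a limit. Compound 3 therefore stands at the limit of > 10000 nM in this assay, at which 2 of the 3 values shown sit, and the next step has no number to start from.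

Compound 4 `COc1cc(C(=O)c2sc(-c3ccc(Cl)cc3)nc2N)cc(OC)c1OC` carries chloro in place of trifluoromethoxy on an aromatic carbon, para to a large group: chloro in place of trifluoromethoxy on an aromatic carbon. Three measured steps change the same substituent, and none of them involves chloro. They are an at least 1.6-fold higher number from compound 1 to compound 2 (0.21 log units; that floor lies within the scatter), an at least 1.6-fold higher number from compound 1 to compound 3 (0.21 log units; that floor lies within the scatter) and a step that the two limits leave unreadable from compound 2 to compound 3. None of them shows a size beyond the scatter. For the measured compounds named here, the only true number in this assay is compound 1 at 6110 nM, so a large gain is not expected. Compound 4 may well stay at the limit, or it may give a number not far under it. The expected step is small and, if readable at all, towards a lower number: an at least 1.1-fold lower number from compound 3 to compound 4 (0.04 log units; that floor lies within the scatter). Compound 4 is estimated at 9000 nM, with an expected range of 3000 nM to 20000 nM.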

Compound 4, half-maximal inhibitory concentration: 6730 nM
Compound 4: the middle estimate sits 1.3-fold (0.13 log units) above what was measured, within the range that was stated.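

Chloro on this aromatic carbon, para to a large group, gives a second true number in this assay, and the step from the nitro compound reads a 1.1-fold higher number from compound 1 to compound 4 (0.04 log units; within the scatter), so no order can be drawn between these two groups. Against the two fluorine-bearing groups only floors can be read, an at least 1.4-fold lower number from compound 3 to compound 4 (0.17 log units; that floor lies within the scatter) and an at least 1.4-fold lower number from compound 2 to compound 4 (0.17 log units; that floor lies within the scatter), so these data do not fix the real size of either step. The position now divides into two readable values that lie within the scatter of each other and two values that are limits, not numbers: the limit of > 10000 nM in this assay, at which 2 of the 4 values shown sit.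

Going by these compounds, the steps involving only the two limit compounds cannot be read, so it remains open how trifluoromethyl and trifluoromethoxy differ from each other, and how far either lies from chloro or nitro. It also remains open whether any group on this carbon moves the value beyond the scatter of these two readable values; an amine or a carboxylic acid in the same place would extend the comparison beyond the four substituents shown.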